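Adding butyl to the chain of compound 3

A few compounds are considered here, and "the series" means these few. Any claim that something is new, unique, unknown or untested is made for them only; others in the source may bear on it.

In a functional assay on HEL cells (Homo sapiens) for cytotoxicity (a lower number here means that less compound is tolerated, a higher number that more compound is tolerated), compound 3 (`CCCCC#Cc1cc2cn([C@@H]3O[C@H](CO)[C@@H](O)[C@@H]3O)c(=O)nc2o1`) gives > 144000 nM, which is a limit and not a number. Compound 1 (`CCCCC#Cc1cc2cn([C@@H]3O[C@H](CO)[C@@H](O)[C@H]3O)c(=O)nc2o1`) gives > 144000 nM, also a limit. Compound 2 (`CCCCCCCCCCC#Cc1cc2cn(C)c(=O)nc2o1`) gives > 150000 nM, again a limit. Compound 3 therefore has no readable position among these compounds. Compound 4 (`CCCCCCCCC#Cc1cc2cn([C@@H]3O[C@H](CO)[C@@H](O)[C@@H]3O)c(=O)nc2o1`) differs from compound 3 by butyl in place of hydrogen on a saturated chain carbon, four bonds along the chain from a triple-bonded carbon. Going by the values given here, the only measured step is a step that the two limits leave unreadable from compound 1 to compound 3, and it concerns (the fact that compounds 1 and 3 differ only in the configuration as drawn), not the chain. With no readable step to guide it, no change beyond the usual scatter is expected in this assay. The estimated step is an at least 1.2-fold lower number from compound 3 to compound 4 (0.07 log units; that floor lies within the scatter). Compound 4 is expected at 120000 nM, with an estimated range of 50000 nM to 170000 nM.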

Compound 4, half-maximal cytotoxic concentration: > 124000 nM
Compound 4: no number, only a limit; the forecaster's own chance of this, stated with the estimate: 80%; at least 1.0-fold (0.01 log units) between middle value and limit.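

In this assay compound 3 and compound 4 are both recorded only as limits, so no step can be read between them. The compounds shown leave open whether adding butyl to the chain changes the cytotoxic concentration at all.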